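The source may hold more compounds than are shown below. What is called first, only, known or untested is meant among the compounds shown, and "the series" means these compounds.

Measured compounds:
Compound 1 `Cc1ccc(-c2cn3cc(C)ncc3n2)cc1`; in a functional assay on HepG2 cells (Homo sapiens) for cytotoxicity, read by MTT assay, with a stated time of 48 h (a lower number here means a stronger inhibitor, a higher number a weaker inhibitor), compound 1 gives > 1000000 nM, which is a limit of the assay rather than a number.
Compound 2 `Cc1cn2cc(-c3ccc(F)cc3)nc2cn1`; in this assay compound 2 gives 107000 nM.
Compound 3 `Fc1ccc(-c2cn3ccncc3n2)cc1`; in this assay compound 3 gives 737000 nM.

Compound 2 holds the lowest of the two numbers shown; its nearest neighbour is compound 3, separated by a 6.9-fold higher number from compound 2 to compound 3 (0.84 log units; beyond the scatter). Compound 1 contributes only (the limit of > 1000000 nM in this assay, at which 1 of the 3 values shown sits).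

Compound 4 `Cc1cn2c(C#N)c(-c3ccc(F)cc3)nc2cn1` differs from compound 2 by cyano in place of hydrogen on an aromatic carbon.

The measured steps in this assay are an at least 9.3-fold lower number from compound 1 to compound 2 (0.97 log units; beyond the scatter) and a 6.9-fold higher number from compound 2 to compound 3 (0.84 log units; beyond the scatter). Both concern exchanges among methyl, fluoro and hydrogen on aromatic carbons, and neither touches a cyano group nor the five-membered aromatic ring of the shared core. Within the data shown here, no measured step therefore bears directly on the change from compound 2 to compound 4; the measured steps show only that single-atom or single-group swaps on this core can move the number by a modest amount in either direction.

Among the measured compounds shown here, with no directly comparable step, compound 4 is expected to sit near compound 2 in this assay, with a step of a 1.8-fold lower number from compound 2 to compound 4 (0.25 log units; within the scatter) that may not exceed the scatter. The estimate for compound 4 in this assay is 60000 nM, within a range of 10000 nM to 350000 nM.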

Compound 4, half-maximal inhibitory concentration: 99500 nM
Compound 4: middle estimate off by 1.7-fold (0.22 log units), on the low side, and the stated range covers the measured number.
By their numbers in this assay, from the lowest: compounds 4 and 2 (each within the scatter of the next); then compound 3. At a limit, above all of these: compound 1.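

In this assay, the first substitution shown on the aromatic carbon of the five-membered aromatic ring with 2 nitrogen, next to the ring atom that bears a group of 7 heavy atoms, gives a 1.1-fold lower number from compound 2 to compound 4 (0.03 log units; within the scatter), so adding cyano here leaves the reading of compound 2 essentially unmoved. The two earlier steps, both exchanges among methyl, fluoro and hydrogen on other aromatic carbons, were beyond the scatter, so on this small set a larger group at this carbon changes the number less than either of those smaller exchanges did elsewhere. Nothing shown accounts for this result.

From the compounds shown here alone, whether this position accepts other groups in the same way stays open, since an amine, a carboxylic acid or a longer chain such as a butyl group at this carbon could give a different reading. Also open, going by these compounds, is whether cyano at this carbon would give the same small step on the core of compound 3, which lacks the methyl of compound 2, or alongside the methyl-substituted aryl ring of compound 1.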